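The source may hold more compounds than are shown below. What is called first, only, known or untested is meant among the compounds shown, and "the series" means these compounds.

In a functional assay on K562 cells (Homo sapiens), read by MTT assay, with a stated time of 72 h (on this read-out lower numbers stand for stronger inhibition and higher numbers for weaker inhibition), compound 1 `C#Cc1cn([C@@H]2O[C@H](CO)[C@@H](O)[C@H]2O)c2ncnc(NC)c12` gives 1380 nM. Compound 2 `CNc1ncnc2c1c(-c1ccoc1)cn2[C@@H]1O[C@H](CO)[C@@H](O)[C@H]1O` gives only a limit, > 20000 nM, in this assay. Compound 2 thus stands at the limit of > 20000 nM in this assay, at which 1 of the 2 values shown sits. Going by the values given here, the one measured step, an at least 14-fold higher number from compound 1 to compound 2 (1.16 log units; beyond the scatter), shows what the move to a furan cost. Compound 3 `CNc1ncnc2c1c(-c1ccco1)cn2[C@@H]1O[C@H](CO)[C@@H](O)[C@H]1O` differs from compound 2 by furan-2-yl in place of furan-3-yl on an aromatic carbon. Among the compounds with values here, no measured step compares the two furans, so no change beyond the scatter is expected, and compound 3 is expected to sit near the limit as well. Compound 3 is estimated at 20000 nM, between 6000 nM and 40000 nM. The expected step is a number no higher from compound 2 to compound 3 (the limit leaves the size open).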

Compound 3, half-maximal inhibitory concentration: 15100 nM
Beside the measured number, compound 3's estimate is 1.3-fold (0.12 log units) above it, and the stated range covers the measured number.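

With furan-2-yl in place of ethynyl, the cost of a furan at this aromatic carbon in this assay now has a measured size: an 11-fold higher number from compound 1 to compound 3 (1.04 log units; beyond the scatter). Between the two furans the step reads an at least 1.3-fold lower number from compound 2 to compound 3 (0.12 log units; that floor lies within the scatter), so the result does not separate furan-2-yl from furan-3-yl. The value of compound 2 remains a limit and not a number: the limit of > 20000 nM in this assay, at which 1 of the 3 values shown sits. The compounds shown leave open whether a nitrile, an amine or a longer chain on this aromatic carbon would keep the activity seen with ethynyl in compound 1.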